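Adding a second chloro to compound 2

The source may hold more compounds than are shown below. What is called first, only, known or untested is meant among the compounds shown, and "the series" means these compounds.

In a functional assay on HT-29 cells (Homo sapiens) (on this read-out lower numbers stand for stronger inhibition of growth and higher numbers for weaker inhibition of growth), compound 1 `N#Cc1ccc(/C=C/S(=O)(=O)Cc2ccc(Nc3ncnc4ccccc34)cc2)cc1` reaches only a limit, > 100000 nM, and not a number. Going by the values given here, compound 2 `O=S(=O)(/C=C/c1ccc(Cl)cc1)Cc1ccc(Nc2ncnc3ccccc23)cc1` gives 73000 nM, the only actual number on this read-out so far. Among the compounds with values here, the single measured step, an at least 1.3-fold lower number from compound 1 to compound 2 (0.13 log units; that floor lies within the scatter), puts chloro in place of cyano on an aromatic carbon. It is bounded by the limit of > 100000 nM in this assay, at which 1 of the 2 values shown sits, so it offers a floor and not a size. Compound 3 `O=S(=O)(/C=C/c1ccc(Cl)cc1Cl)Cc1ccc(Nc2ncnc3ccccc23)cc1` differs from compound 2 by chloro in place of hydrogen on an aromatic carbon, taking 4-chlorophenyl to 2,4-dichlorophenyl. Within the data shown here, no measured step puts chloro in place of hydrogen, so the guide is loose. In this assay a small shift toward a lower number is expected, a 1.5-fold lower number from compound 2 to compound 3 (0.16 log units; within the scatter), and it would not be expected to pass beyond the scatter. Compound 3 is estimated at 50000 nM, with an expected range of 20000 nM to 100000 nM.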

Compound 3, concentration for 50% growth inhibition: 24000 nM
Beside the measured number, compound 3's estimate is 2.1-fold (0.32 log units) above it; the range from low to high includes it.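

In this assay, going by these compounds alone, the new chloro gives the first step on this read-out between two actual numbers: a 3.0-fold lower number from compound 2 to compound 3 (0.48 log units; beyond the scatter). It shows that a change on the aromatic carbon ortho to a large group and meta to a chloro group can move the number beyond the scatter, which the earlier step, with its floor within the scatter, could not show. The wider change reads an at least 4.1-fold lower number from compound 1 to compound 3 (0.61 log units; beyond the scatter), and this too is a floor and not a size: the limit of > 100000 nM in this assay, at which 1 of the 3 values shown sits.

The compounds shown leave open whether a fluoro, a methoxy or an amine on that same carbon would move the number as chloro does. They also leave open whether chloro there would give the same step without the other chloro group on the ring.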